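The source may hold more compounds than are shown below. What is called first, only, known or untested is meant among the compounds shown, and "the series" means these compounds.

Measured in a functional assay on DU-145 cells (Homo sapiens) for cytotoxicity, read by trypan blue exclusion, with a stated time of 96 h; a higher number here means a weaker inhibitor, a lower number a stronger inhibitor:
- compound 1 `COC(=O)C(C)(C)Nc1cc(CS(=O)(=O)/C=C/c2c(OC)cc(OC)cc2OC)ccc1OC`: 2500 nM
- compound 2 `COC(=O)C(Nc1cc(CS(=O)(=O)/C=C/c2c(OC)cc(OC)cc2OC)ccc1OC)c1ccc(F)cc1`: 300 nM
- compound 3 `COC(=O)C(Nc1cc(CS(=O)(=O)/C=C/c2c(OC)cc(OC)cc2OC)ccc1OC)c1ccc(Cl)cc1`: 400 nM

Compound 3 stands level with compound 2, as the gap is only a 1.3-fold higher number from compound 2 to compound 3 (0.12 log units; within the scatter), and well clear of compound 1, as shown by a 6.3-fold lower number from compound 1 to compound 3 (0.80 log units; beyond the scatter). Compound 4 `COC(=O)C(Nc1cc(CS(=O)(=O)/C=C/c2c(OC)cc(OC)cc2OC)ccc1OC)c1ccc(Br)cc1` has bromo in place of chloro on an aromatic carbon. The closest guide is the swap of fluoro for chloro at that same place, the step of a 1.3-fold higher number from compound 2 to compound 3 (0.12 log units; within the scatter). The larger step of an 8.3-fold lower number from compound 1 to compound 2 (0.92 log units; beyond the scatter) replaced a whole group, so it says little here. The expected result in this assay is therefore no change at the digits printed from compound 3 to compound 4 (within the scatter), with no shift beyond the scatter expected in either direction. For compound 4 the estimate is 400 nM, with an expected range of 180 nM to 850 nM.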

Compound 4, half-maximal inhibitory concentration: 300 nM
Estimate against measurement, compound 4: 1.3-fold (0.12 log units) above, within the range that was stated.
By their numbers in this assay, from the lowest: compounds 2, 4 and 3 (each within the scatter of the next); then compound 1.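

In this assay, bromo now joins fluoro and chloro on this aromatic carbon with no step beyond the scatter (first a 1.3-fold lower number from compound 3 to compound 4 (0.12 log units; within the scatter), then no change at the digits printed from compound 2 to compound 4 (within the scatter)), so these three halogens cannot be told apart here. The 4-bromophenyl group also keeps the gain over the group carried by compound 1 (an 8.3-fold lower number from compound 1 to compound 4 (0.92 log units; beyond the scatter)). Nothing available explains why the swap among halogens leaves the number so steady. Still open, from the compounds shown here alone, is whether a non-halogen group at this place, such as an amine, a nitrile or a carboxylic acid, would hold the number in this range.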